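A few compounds are considered here, and "the series" means these few. Any claim that something is new, unique, unknown or untested is made for them only; others in the source may bear on it.

In an ADME assay on Vero cells (Chlorocebus sabaeus) for cytotoxicity, read by MTT assay, with a stated time of 72 h (a higher number here means that more compound is tolerated, a lower number that less compound is tolerated), compound 1 `C[C@]1(CN2CCc3nc(-c4ccc(F)c(F)c4)oc3C2)Cn2cc([N+](=O)[O-])nc2O1` gives only a limit of the assay, > 32 ug/mL. Compound 2 `C[C@]1(CN2CCc3nc(C4CCOCC4)ccc3C2)Cn2cc([N+](=O)[O-])nc2O1` shares the same core but carries oxan-4-yl, and for compound 2 the entry in this assay reads "not determined" (no result reported), so it has no number of its own to stand on. Compound 3 `C[C@]1(CN2CCc3nc(-c4cc(F)cc(Cl)c4)ccc3C2)Cn2cc([N+](=O)[O-])nc2O1` differs from compound 2 in one place: 3-chloro-5-fluorophenyl in place of oxan-4-yl on an aromatic carbon. No step between two measured compounds is shown, so the size of this change in this assay cannot be read from the data, and no shift beyond the usual scatter is assumed in either direction. Compound 3 is expected to sit near 32 ug/mL, within 16 ug/mL to 64 ug/mL, quite possibly again reported only as a limit.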

Compound 3, half-maximal cytotoxic concentration: > 32 ug/mL
Compound 3 was reported as a limit (the forecaster's own chance of this, stated with the estimate: 65%); the middle value sits exactly at the limit.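

No step can be read from these results: compound 2 has no reported result, and compound 3 gives only a limit. Left open is whether replacing oxan-4-yl with 3-chloro-5-fluorophenyl changes cell tolerance at all.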